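Swapping ethyl for hydrogen on compound 1

The source may report more compounds than this note shows. Statements on the series, on what has been measured and on what is new or still open speak of the compounds shown alone.

Within the data shown here, in a functional assay on Maver1 cells (Homo sapiens) for inhibition, read by luminescence and CellTiter-Glo, with a stated time of 72 h (a higher number here means a weaker inhibitor, a lower number a stronger inhibitor), compound 1 (`C/C=C/C(=O)N1CCCC(n2nc(-c3ccc(Oc4ccccc4)cc3)cc2C(=O)OCC)C1`) gives 19600 nM and holds the higher of the two exact numbers so far. Compound 2 (`O=C(CCl)Nc1ccc(Cn2nc(-c3ccc(Oc4ccccc4)cc3)cc2C(=O)O)cc1`) gives 1200 nM and sits clearly lower, but it differs from compound 1 in more than one place. Compound 3 (`C=CC(=O)N1CCCC(n2nc(-c3ccc(Oc4ccccc4)cc3)cc2C(=O)OCC)C1`) reads > 60000 nM as a limit, not a number.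

Compound 4 (`C/C=C/C(=O)N1CCCC(n2nc(-c3ccc(Oc4ccccc4)cc3)cc2C(=O)O)C1`) is compound 1 with hydrogen in place of ethyl on an oxygen next to a carbonyl group, which turns ethoxycarbonyl into carboxy. Among the measured compounds shown here, the only measured single change (an at least 3.0-fold higher number from compound 1 to compound 3 (0.48 log units; beyond the scatter)) puts vinyl in place of prop-1-en-1-yl on a carbonyl carbon, elsewhere in the molecule, so it does not size this swap. For the measured compounds named here, the one hint is that compound 2 also carries carboxy and gives 1200 nM in this assay as its value. A modest move to a lower number is therefore expected, though no change remains possible. The expected step is a 2.2-fold lower number from compound 1 to compound 4 (0.34 log units; beyond the scatter) in this assay as a rough guess. For compound 4 the estimated value is 9000 nM with an expected range of 2000 nM to 35000 nM in this assay readings.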

Compound 4, half-maximal inhibitory concentration: > 60000 nM
Compound 4: a limit, no number; the forecaster's own chance of this, stated with the estimate: 10%; middle value at least 6.6-fold (0.82 log units) away from the limit.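

Ethyl on the oxygen next to a carbonyl group matters in this series: hydrogen in its place, which turns ethoxycarbonyl into carboxy, gives an at least 3.0-fold higher number from compound 1 to compound 4 (0.48 log units; beyond the scatter) in this assay. Compound 4 reads > 60000 nM, which is a limit of the assay and not a number. So a second place in compound 1, apart from the prop-1-en-1-yl group, can also push the number upward, and the full size of this step stays unknown since the reading is a limit: the limit of > 60000 nM in this assay, at which 2 of the 4 values shown sit.

The compounds shown leave open whether ethyl is specifically needed on this oxygen, or whether methyl or a longer chain would serve as well. They also leave open how a primary amide in place of ethoxycarbonyl would read on the core of compound 1.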